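Trading cyclohexyl for a short chain in compound 4

The source may report more compounds than this note shows. Statements on the series, on what has been measured and on what is new or still open speak of the compounds shown alone.

Compound 1 `CC(C)CC1OCCC(Cl)=C1[Si](C)(C)C`: 65000 nM
Compound 2 `C[C@H]1CC(Cl)=C([Si](C)(C)C)[C@@H](C2CCCCC2)O1`: 62000 nM
Compound 3 `C[C@@H]1O[C@H](C2CCCCC2)C([Si](C)(C)C)=C(Cl)[C@H]1C`: 76000 nM

The read-out is a functional assay on SW1573 cells (Homo sapiens) for antiproliferative activity; on this read-out lower numbers stand for higher toxicity in this test and higher numbers for lower toxicity in this test. Compound 3 gives the highest of the three numbers, but its gaps to compound 1 and compound 2 are within the scatter, so the three stand level. Among the compounds with values here, the only measured step, a 1.2-fold higher number from compound 2 to compound 3 (0.09 log units; within the scatter), is also within the scatter. Compound 4 `C=CCC[C@H]1O[C@@H](C)[C@H](C)C(Cl)=C1[Si](C)(C)C` differs from compound 3 by but-3-en-1-yl in place of cyclohexyl on a saturated ring carbon. Within the data shown here, no measured step swaps this group, but compound 1 carries a chain without a ring and gives 65000 nM, level with compound 2. Compound 4 is therefore expected to show no step beyond the scatter, a 1.1-fold lower number from compound 3 to compound 4 (0.04 log units; within the scatter). The estimate for compound 4 is 70000 nM, with a range from 30000 nM to 160000 nM.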

Compound 4, concentration lethal to 50% of the cells: 92000 nM
Beside the measured number, compound 4's estimate is 1.3-fold (0.12 log units) below it, within the range that was stated.
By their numbers in this assay, from the lowest: compounds 2, 1, 3 and 4 (each within the scatter of the next).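

On this saturated ring carbon next to the ring oxygen, but-3-en-1-yl in place of cyclohexyl gives a 1.2-fold higher number from compound 3 to compound 4 (0.08 log units; within the scatter) in this assay. The cyclohexyl ring can thus give way to an open chain with a double bond, with no step beyond the scatter in this test. No evidence at hand explains this result.

The compounds shown leave open how a saturated butyl chain, a longer chain or a chain ending in an amine would read at this position. They also leave open whether the double bond plays any part.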